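A few compounds are considered here, and "the series" means these few. Any claim that something is new, unique, unknown or untested is made for them only; others in the source may bear on it.

Measured in a physicochemical assay for lipophilicity (on this read-out higher numbers stand for higher lipophilicity and lower numbers for lower lipophilicity), so far:
Compound 1 `O=C(CN(C(=O)C1CCOCC1)C1CCCCC1)Nc1cc(F)cc(F)c1` gives 3
Compound 2 `O=C(CN(C(=O)c1cccnc1)C1CCCCC1)Nc1cc(F)cc(F)c1` gives 2.7
Compound 3 `O=C(CN(C(=O)c1ccc(-n2ccnc2)cc1)C1CCCCC1)Nc1cc(F)cc(F)c1` gives 2.7

Compound 3 stands level with compound 2 and within the scatter of compound 1. Compound 4 `O=C(CN(C(=O)c1ccc(-c2ccccn2)cc1)C1CCCCC1)Nc1cc(F)cc(F)c1` departs from compound 3 by pyridin-2-yl in place of 1H-imidazol-1-yl on an aromatic carbon and by nothing else. Among the measured compounds shown here, no measured step covers this exchange. The nearest, a number 0.30 log units lower from compound 1 to compound 2 (within the scatter) and also a swap of one ring for another, stays within the scatter and offers only weak guidance. A modest upward step in this assay is nevertheless expected, resting on the exchange itself and without direct support from the measurements. The expected move is a number 0.60 log units higher from compound 3 to compound 4 (beyond the scatter) by this estimate. For compound 4 the estimate is 3.3 with 2.9 to 3.8 as its expected range.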

Compound 4, distribution coefficient: 3.7
Compound 4: middle estimate off by 0.40 log units, on the low side; low and high end bracket the measured number.
By their numbers in this assay, from the lowest: compounds 2, 3 and 1 (each within the scatter of the next); then compound 4.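

In this assay, the aromatic carbon para to a large group proves sensitive to which ring it carries: pyridin-2-yl in place of 1H-imidazol-1-yl gives a number 1.00 log units higher from compound 3 to compound 4 (beyond the scatter), the only step shown that lies beyond the scatter. A change from one aromatic ring to another at this position can therefore move the read-out clearly. Nothing available accounts for this step. The compounds shown leave open whether a phenyl or a morpholine group at this position would read closer to compound 3 or to compound 4.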